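The compounds below may be only part of what the source reports. "The series", "measured", "known", "first", "only" and "open" are said of these compounds alone.

Of the compounds shown here, three with a shared core have been measured in a physicochemical assay for lipophilicity, at pH 7.4; a higher number here means a more lipophilic compound, a lower number a more polar compound. Compound 1 `O=C1CC(C2CCOCC2)Oc2ccc(S(=O)(=O)N3CCCC3c3ccccc3C(F)(F)F)cc21` gives 3.5, compound 2 `CC(C)CN(C1CCc2ccc(F)cc21)S(=O)(=O)c1ccc2c(c1)C(=O)CC(C1CCOCC1)O2` gives 4.03, and compound 3 `CCc1ccc(N(CC2CCC2)S(=O)(=O)c2ccc3c(c2)C(=O)CC(C2CCOCC2)O3)cc1` gives 4.1. Compound 3 and compound 2 cannot be told apart, since their values lie within the usual scatter of repeated measurements. Compound 1 sits lower than compound 3, by a margin beyond that scatter.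

Compound 4 `CCc1ccc(N(CC2CC2)S(=O)(=O)c2ccc3c(c2)C(=O)CC(C2CCOCC2)O3)cc1` has not yet been measured. It differs from compound 3 in one place: cyclopropyl in place of cyclobutyl on a saturated chain carbon bound to a sulfonamide nitrogen. Put simply, cyclopropyl stands in place of cyclobutyl on a saturated chain carbon bound to a sulfonamide nitrogen, so that cyclobutylmethyl becomes cyclopropylmethyl. Going by the values given here, no measured pair of compounds here shows this change on its own, so the expectation rests on the structural change alone. A small fall in this assay is expected, with the estimated a number 0.30 log units lower from compound 3 to compound 4 (within the scatter) no larger than the scatter. For compound 4 the estimated value is 3.8, with an expected range from 3.5 to 4.05.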

Compound 4, distribution coefficient: 3.77
For compound 4 the middle estimate is 0.03 log units above the measured one; low and high end bracket the measured number.
By their numbers in this assay, from the lowest: compounds 1, 4, 2 and 3 (each within the scatter of the next, the first and the last beyond it).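

Going by these compounds alone, compound 3 and compound 4 form the first pair here that differ in only one place, so this is the first direct reading of this position: in this assay, the exchange of cyclobutyl for cyclopropyl gives a number 0.33 log units lower from compound 3 to compound 4 (beyond the scatter). The step is modest, yet it shows that going from 4 heavy atoms to 3 on a saturated chain carbon bound to a sulfonamide nitrogen can move this number measurably, even though the hydrogen-bond donor and acceptor counts and the net charge stay the same. No measurement shown here bears on the cause of this step.

A single pair cannot show whether the same exchange would give a similar step in other compounds. Going by these compounds, how a cyclopentyl ring, a longer chain or an amine would read at this place also remains open.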